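The compounds below may be only part of what the source reports. "The series", "measured", "known", "first", "only" and "open" are said of these compounds alone.

Of the compounds shown here, three have so far been tested in a functional assay on the whole organism (strain Wistar) for inhibition, with Rattus norvegicus as the target, read by paw edema, with a stated time of 2 h, at a dose of 10 mg/kg by the intraperitoneal route; on this read-out higher numbers stand for more inhibition at the one dose given (going by the name of the read-out) and lower numbers for less inhibition. Compound 1 `O=C(N/N=C/c1ccccc1)c1cccnc1Nc1cccc(C(F)(F)F)c1` gives 36.8% in this assay. Compound 2 `O=C(N/N=C/c1cccnc1)c1cccnc1Nc1cccc(C(F)(F)F)c1` carries a single change from compound 1: pyridin-3-yl in place of phenyl on a carbon with a double bond to nitrogen In this assay compound 2 gives 62.4%, and the step of a number 25.6 percentage points higher from compound 1 to compound 2 (beyond the scatter) lies beyond the usual scatter of repeated measurements. Compound 3 `CNc1ncccc1C(=O)N/N=C/c1ccccc1` rests on a different core; the difference between the core of compound 3 and the core of compound 1 is not broken down here. In this assay compound 3 gives 47.2%, which places it second highest of the three, above compound 1 and below compound 2.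

Compound 4 `CNc1ncccc1C(=O)N/N=C/c1cccnc1` has not yet been measured. It differs from compound 3 in one place only: pyridin-3-yl in place of phenyl on a carbon with a double bond to nitrogen This is the same change, at the same place, that turns compound 1 into compound 2, and it occurs twice among the four compounds. Within the data shown here, only one measured pair shows what the change does, and that pair sits on a different core, so carrying it over to compound 3 is an inference rather than a certainty. For compound 4 the expected step is a number 20.8 percentage points higher from compound 3 to compound 4 (beyond the scatter), a little smaller than the earlier one, because the step of a number 25.6 percentage points higher from compound 1 to compound 2 (beyond the scatter) rests on a single pair. Compound 4 is therefore estimated at 68%, with a likely range from 50% to 84%.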

Compound 4, a percentage reported as inhibition, in the whole organism at one dose (the size of the read-out at that dose, not a potency): 43.7%
Compound 4: middle estimate off by 24.3 percentage points, on the high side; the whole stated range lies above it.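

In this assay, the swap of phenyl for pyridin-3-yl on a carbon with a double bond to nitrogen does not repeat on the core of compound 3 what it did on the core of compound 1: here the change gives a number 3.5 percentage points lower from compound 3 to compound 4 (within the scatter), so compound 3 and compound 4 cannot be told apart on this read-out. The same swap therefore does not behave alike on these two cores, and a gain measured on one of them cannot simply be added to a compound built on the other: the same change on two cores in this assay, a number 25.6 percentage points higher (beyond the scatter) from compound 1 to compound 2 and a number 3.5 percentage points lower (within the scatter) from compound 3 to compound 4, 29.1 percentage points apart, beyond the scatter of two such steps. Among these compounds, this does not show which part of the two cores makes the difference or why it arises, and with only one pair on each core it gives no general rule for how this swap behaves across the series.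

The compounds shown leave open whether a third core would follow the core of compound 1, the core of compound 3, or neither. They also leave open how either core would respond to other groups at the same place, such as pyridin-4-yl or a phenyl ring carrying an amine or a carboxylic acid.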